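This account rests on a few compounds, and the source may have more. Where it says the series, first, only, none or still open, it means among the compounds named here.

Three compounds with one shared core differ only in the group on a double-bonded chain carbon bound to a double-bonded chain carbon. In a functional assay on HCT-116 cells (Homo sapiens) for antiproliferative activity, read by MTT assay, with a stated time of 24 h (a higher number here means a weaker inhibitor, a lower number a stronger inhibitor), compound 1 `COc1ccc(C(=O)/C=C/c2cccc(F)c2)c2c1C=CC(C)(C)O2` reaches only the assay limit of > 10000 nM. Compound 2 `COc1ccc(C(=O)/C=C/c2ccc(Br)cc2)c2c1C=CC(C)(C)O2` likewise stops at the limit of > 10000 nM. Compound 3 `COc1ccc(C(=O)/C=C/c2cccs2)c2c1C=CC(C)(C)O2` also gives only the limit of > 10000 nM. Because all three sit at the limit of > 10000 nM in this assay, at which 3 of the 3 values shown sit, the steps a step that the two limits leave unreadable from compound 1 to compound 2, a step that the two limits leave unreadable from compound 1 to compound 3 and a step that the two limits leave unreadable from compound 2 to compound 3 cannot be read in size or direction. Compound 4 `COc1ccc(C(=O)/C=C/c2ccc(Cl)c(Cl)c2)c2c1C=CC(C)(C)O2` carries 3,4-dichlorophenyl in place of thiophen-2-yl on a double-bonded chain carbon bound to a double-bonded chain carbon. For the measured compounds named here, no measured step speaks to this change, and with every neighbour at the limit a value there again is the plain expectation. The step that the limit leaves unreadable from compound 3 to compound 4 is therefore expected to stay within the scatter. Compound 4 is estimated at 12000 nM, between 3000 nM and 40000 nM in this assay.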

Compound 4, half-maximal inhibitory concentration: 9440 nM
Estimate against measurement, compound 4: 1.3-fold (0.10 log units) above, and the stated range covers the measured number.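

In this assay compound 4 is the first of these compounds to give a readable number rather than a limit, and 3,4-dichlorophenyl on a double-bonded chain carbon bound to a double-bonded chain carbon gives an at least 1.0-fold lower number from compound 3 to compound 4 (0.02 log units; that floor lies within the scatter), an at least 1.0-fold lower number from compound 2 to compound 4 (0.02 log units; that floor lies within the scatter) and an at least 1.0-fold lower number from compound 1 to compound 4 (0.02 log units; that floor lies within the scatter). On these data alone, each step is only a floor, so how far compound 4 truly lies from the others stays unknown. The other compounds all remain at the limit: the limit of > 10000 nM in this assay, at which 3 of the 4 values shown sit.

Open, as far as these compounds go, is whether a pyridin-3-yl or a 4-aminophenyl group at this place would give a number clearly lower than that of compound 4.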